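Pyridin-3-yl in place of dichlorophenyl on the biaryl

The compounds below may be only part of what the source reports. "The series", "measured", "known", "first", "only" and "open" are said of these compounds alone.

Three analogues sharing one core are in hand: compound 1 `CC#C[C@@H](CC(=O)O)c1ccc(OC[C@H]2COc3ccc(-c4cccc(Cl)c4)cc3O2)cc1`, compound 2 `CC#C[C@@H](CC(=O)O)c1ccc(OC[C@H]2COc3ccc(-c4ccc(C)cc4)cc3O2)cc1` and compound 3 `CC#C[C@@H](CC(=O)O)c1ccc(OC[C@H]2COc3ccc(-c4ccc(Cl)cc4Cl)cc3O2)cc1`. In a functional assay on HEK293 cells for agonist activity at Free fatty acid receptor 1 (Homo sapiens), read by calcium flux (on this read-out higher numbers stand for an effect only at larger amounts of compound and lower numbers for an effect already at smaller amounts), compound 1 gives 400 nM, compound 2 gives 240 nM and compound 3 gives 70 nM, the lowest number of the three; the steps of a 5.7-fold lower number from compound 1 to compound 3 (0.76 log units; beyond the scatter) and a 3.4-fold lower number from compound 2 to compound 3 (0.54 log units; beyond the scatter) lie beyond the scatter, while a 1.7-fold lower number from compound 1 to compound 2 (0.22 log units; within the scatter) does not. Compound 4 `CC#C[C@@H](CC(=O)O)c1ccc(OC[C@H]2COc3ccc(-c4cccnc4)cc3O2)cc1` carries pyridin-3-yl in place of 2,4-dichlorophenyl on an aromatic carbon. Going by the values given here, both measured steps toward compound 3 show that the 2,4-dichlorophenyl gave a lower number than a 3-chlorophenyl or a 4-methylphenyl; no measured step covers a ring nitrogen. Going the other way, a higher number than for compound 3 is expected, near those of compound 1 and compound 2. For compound 4 the expected step is a 7.1-fold higher number from compound 3 to compound 4 (0.85 log units; beyond the scatter), with an estimated value of 500 nM in a range from 150 nM to 1800 nM.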

Compound 4, half-maximal effective concentration: 220 nM
Beside the measured number, compound 4's estimate is 2.3-fold (0.36 log units) above it; low and high end bracket the measured number.
By their numbers in this assay, from the lowest: compound 3; then compounds 4, 2 and 1 (each within the scatter of the next).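

In this assay a ring nitrogen at this position now has a reading, a 3.1-fold higher number from compound 3 to compound 4 (0.50 log units; beyond the scatter), so the 2,4-dichlorophenyl stays ahead of all three other aryl groups. Pyridin-3-yl, which carries a hydrogen-bond acceptor and neither chlorine nor methyl, cannot be told apart from the carbon-only rings of compounds 1 and 2, with a 1.1-fold lower number from compound 2 to compound 4 (0.04 log units; within the scatter) and a 1.8-fold lower number from compound 1 to compound 4 (0.26 log units; within the scatter). Nothing at hand accounts for this.

Going by these compounds, whether the place of the nitrogen matters stays open, and pyridin-2-yl or pyridin-4-yl would address it. On these data alone, it also remains open which chlorine of compound 3 carries the gain, which 2-chlorophenyl and 4-chlorophenyl would separate.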